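Lengthening the amine chain: from compound 3 to compound 4

This account rests on a few compounds, and the source may have more. Where it says the series, first, only, none or still open, it means among the compounds named here.

Compound 1 `COc1cc(/C=C/C(=O)Nc2ccccc2)ccc1OCCCN1CCCC1` gives 1.57 in a physicochemical assay for lipophilicity, using the shake flask method, measured as octanol-water partition, at pH 7.4; on this read-out higher numbers stand for higher lipophilicity and lower numbers for lower lipophilicity; compound 2 `CCN(CC)CCCCOc1ccc(/C=C/C(=O)Nc2ccccc2)cc1OC` gives 1.59; compound 3 `COc1cc(/C=C/C(=O)Nc2ccccc2)ccc1OCCCCCCN1CCCCC1` gives 1.77.

Compound 3 sits at a value that compound 1 and compound 2 both match within the scatter: the steps of a number 0.20 log units higher from compound 1 to compound 3 (within the scatter) and a number 0.18 log units higher from compound 2 to compound 3 (within the scatter) are small, as is a number 0.02 log units higher from compound 1 to compound 2 (within the scatter). Compound 4 `CCN(CC)CCCCCCCCOc1ccc(/C=C/C(=O)Nc2ccccc2)cc1OC` differs from compound 3 in one place: 2-(diethylamino)ethyl in place of piperidin-1-yl on a saturated chain carbon, six bonds along the chain from an oxygen on an aromatic ring. The measured steps all swap or extend the amine end with little effect; here the chain grows further. The expected step is a number 0.18 log units higher from compound 3 to compound 4 (within the scatter), a modest rise at the edge of the scatter. Compound 4 is therefore estimated at 1.95, with a likely range from 1.55 to 2.35.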

Compound 4, partition coefficient: 1.75
Compound 4: middle estimate off by 0.20 log units, on the high side; low and high end bracket the measured number.
By their numbers in this assay, from the lowest: compounds 1, 2, 4 and 3 (each within the scatter of the next).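

In this assay, open 2-(diethylamino)ethyl in place of the ring of piperidin-1-yl, six bonds along the chain from an oxygen on an aromatic ring, gives a step within the scatter (a number 0.02 log units lower from compound 3 to compound 4 (within the scatter)), so ring and open chain cannot be told apart here. The steps to the other two compounds (a number 0.16 log units higher from compound 2 to compound 4 (within the scatter); a number 0.18 log units higher from compound 1 to compound 4 (within the scatter)) are also within the scatter, so the four compounds form one group on this read-out. Nothing at hand explains this. From the compounds shown here alone, what a carboxylic acid or a morpholin-4-yl group at the chain end would give remains open.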